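The source may report more compounds than this note shows. Statements on the series, on what has been measured and on what is new or still open speak of the compounds shown alone.

Going by the values given here, compound 2 `CC(Oc1cccnc1Nc1cnn(C)c1)c1cccc(C(=O)NCc2ccc(F)c(Cl)c2)c1` is one of only two compounds measured in a functional assay on HCC78 cells (Homo sapiens) for antiproliferative activity, read by MTT assay, with a stated time of 48 h; on this read-out higher numbers stand for weaker inhibition and lower numbers for stronger inhibition; in this assay compound 2 gives 7800 nM, the lower of the two numbers, while compound 1 `COc1cccc(CNC(=O)c2cccc(C(C)Oc3cccnc3Nc3cnn(C)c3)c2)c1` gives 78600 nM. Among the compounds with values here, the single measured step, a 10-fold lower number from compound 1 to compound 2 (1.00 log units; beyond the scatter), concerns the group on the saturated chain carbon bound to the amide-type nitrogen. Compound 3 `Cc1cnc(Nc2ncccc2OC(C)c2cccc(C(=O)NCc3ccc(F)c(Cl)c3)c2)s1` keeps that part of compound 2 unchanged and differs at another place: 5-methyl-1,3-thiazol-2-yl in place of 1-methyl-1H-pyrazol-4-yl on a nitrogen on an aromatic ring. Within the data shown here, no measured step touches this position, so the step from compound 1 to compound 2 offers no direct guide, and nothing in the data shows in which direction, if any, the number should move. Compound 3 is therefore expected to give about 8000 nM, which amounts to a step of a 1.0-fold higher number from compound 2 to compound 3 (0.01 log units; within the scatter) in this assay, with an estimated range from 2000 nM to 40000 nM that leaves room for a change either way.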

Compound 3, half-maximal inhibitory concentration: 34700 nM
Estimate against measurement, compound 3: 4.3-fold (0.64 log units) below, and the stated range covers the measured number.
By their numbers in this assay, from the lowest: compound 2; then compound 3; then compound 1.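

The nitrogen on an aromatic ring proved to be a position where the group matters in this assay (a 4.4-fold higher number from compound 2 to compound 3 (0.65 log units; beyond the scatter)), a step that lies beyond the scatter. The change moves the number upward even though 1-methyl-1H-pyrazol-4-yl and 5-methyl-1,3-thiazol-2-yl have the same count of heavy atoms, the same ring size and the same counts of hydrogen-bond donors and acceptors, so these counts alone do not set the number in this pair. Nothing available explains the difference.

The compounds shown leave open whether the step follows from the change of ring or from the place of its methyl group, which a thiazol-2-yl without methyl or a 1H-pyrazol-4-yl without methyl would help to separate. They also leave open how a phenyl or a pyridinyl group would behave on this nitrogen.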